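Removing the terminal phosphate from a benzylthio uridine nucleotide

A few compounds are considered here, and "the series" means these few. Any claim that something is new, unique, unknown or untested is made for them only; others in the source may bear on it.

The three measured compounds share a uridine-derived core carrying a sulfur-linked group and a phosphate chain. Compound 1 `CCSc1nc(=O)ccn1[C@@H]1O[C@H](COP(=O)(O)O)[C@@H](O)[C@H]1O` gives 4330 nM in an in vitro functional assay on 1321-N1 cells for agonist activity at P2Y purinoceptor 4 (Homo sapiens), read by scintillation proximity assay and inositol phosphate accumulation; a lower number here means that less compound is needed, a higher number that more compound is needed for the effect. Compound 2 `O=c1ccn([C@@H]2O[C@H](COP(=O)(O)O)[C@@H](O)[C@H]2O)c(SCCc2ccccc2)n1` reaches only the limit of the assay, > 100000 nM, in this assay. Compound 3 `O=c1ccn([C@@H]2O[C@H](COP(=O)(O)OP(=O)(O)O)[C@@H](O)[C@H]2O)c(SCc2ccccc2)n1` gives 5980 nM in this assay, which places it near compound 1, the two numbers lying within the usual scatter of each other. One further value shown is a limit (the limit of > 100000 nM in this assay, at which 1 of the 3 values shown sits).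

Compound 4 `O=c1ccn([C@@H]2O[C@H](COP(=O)(O)O)[C@@H](O)[C@H]2O)c(SCc2ccccc2)n1` differs from compound 3 by a hydrogen atom in place of a group of 4 heavy atoms (3 oxygen, 1 phosphorus; no ring), on an oxygen. Going by the values given here, the only measured step with a single change, an at least 23-fold higher number from compound 1 to compound 2 (1.36 log units; beyond the scatter), concerns the sulfur-linked side chain, not the phosphate chain, so it does not speak directly to this change. Without a comparable measured step, the direction for compound 4 cannot be read from the shown numbers, and the expectation rests on the benzylthio chain of compound 3 sitting between the ethylthio chain of compound 1 and the phenethyl chain of compound 2. Compound 4 is therefore estimated at 20000 nM, within a range of 4000 nM to 100000 nM, an expected step of a 3.3-fold higher number from compound 3 to compound 4 (0.52 log units; beyond the scatter).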

Compound 4, half-maximal effective concentration: > 100000 nM
Compound 4 was reported as a limit (the forecaster's own chance of this, stated with the estimate: 30%); middle value at least 5.0-fold (0.69 log units) from the limit.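

With the benzylthio chain held fixed, a hydrogen atom in place of the terminal phosphate group, on an oxygen bound to phosphorus, gives an at least 16-fold higher number from compound 3 to compound 4 (1.22 log units; beyond the scatter) in this assay. Going by these compounds alone, this is the only measured step here at the phosphate chain, and it shows that with this side chain the terminal phosphate group makes a large difference to the number. With a single phosphate held fixed, phenyl in place of methyl on the saturated chain carbon bound to a sulfur gives an at least 23-fold higher number from compound 1 to compound 4 (1.36 log units; beyond the scatter), so the ethylthio chain of compound 1 stays measurable while the benzylthio and phenethyl chains both end at a limit, and the step between those two limits cannot be read: the limit of > 100000 nM in this assay, at which 2 of the 4 values shown sit.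

As far as these compounds go, it remains open whether the terminal phosphate group matters as much with the ethylthio chain of compound 1 as it does with the benzylthio chain. Also open, from the compounds shown here alone, is how a triphosphate chain, a propylthio chain or a benzyl group carrying an amine would read in this assay.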